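Methyl on the Three-Membered Ring: the Other Stereoisomer

This account rests on a few compounds, and the source may have more. Where it says the series, first, only, none or still open, it means among the compounds named here.

Measured compounds:
compound 1, `CC(=O)O[C@@H](C)/C=C\C(=O)N[C@@H]1C[C@H](C)[C@H](C/C=C(C)/C=C/[C@H]2OCC[C@@]3(CO3)[C@@H]2O)O[C@@H]1C`, in a functional assay on CWR22R cells (Homo sapiens), read by flow cytometry, with a stated time of 3 days (a lower number here means a stronger inhibitor, a higher number a weaker inhibitor), compound 1 gives 3.3 nM
compound 2, `CC(=O)O[C@@H](C)/C=C\C(=O)N[C@@H]1C[C@H](C)[C@H](C/C=C(C)/C=C/[C@H]2OCC[C@]3(O[C@@H]3C)[C@@H]2O)O[C@@H]1C`, in this assay compound 2 gives 202 nM

For the measured compounds named here, compound 1 holds the lowest of the two numbers measured so far; the nearest is compound 2, which sits a 61-fold higher number from compound 1 to compound 2 (1.79 log units; beyond the scatter) away from it. That step came from one change only, methyl in place of hydrogen on a saturated ring carbon with one spatial arrangement at the new carbon.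

Compound 3, `CC(=O)O[C@@H](C)/C=C\C(=O)N[C@@H]1C[C@H](C)[C@H](C/C=C(C)/C=C/[C@H]2OCC[C@]3(O[C@H]3C)[C@@H]2O)O[C@@H]1C`, is the untested partner of that pair. It differs from compound 1 by methyl in place of hydrogen on a saturated ring carbon, placed on a saturated ring carbon of a three-membered non-aromatic ring with one oxygen, next to the ring oxygen, but with the opposite spatial arrangement to compound 2. Going by the values given here, the only step that bears on it is a 61-fold higher number from compound 1 to compound 2 (1.79 log units; beyond the scatter), which was large and beyond the scatter. The same group at the same place is therefore expected to weaken compound 3 in this assay as well, though the different arrangement leaves the size uncertain; the estimated step is an 18-fold higher number from compound 1 to compound 3 (1.26 log units; beyond the scatter). Compound 3 is expected to give about 60 nM, with a likely range from 8 nM to 400 nM.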

Compound 3, half-maximal inhibitory concentration: 187 nM
For compound 3 the middle estimate is 3.1-fold (0.49 log units) below the measured one; the range from low to high includes it.
By their numbers in this assay, from the lowest: compound 1; then compounds 3 and 2 (each within the scatter of the next).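

Placed with the opposite spatial arrangement to compound 2, the methyl still brings a large loss in this assay, a 57-fold higher number from compound 1 to compound 3 (1.75 log units; beyond the scatter), so the weakening is not confined to one arrangement at the new carbon. The two arrangements give numbers that cannot be told apart, a 1.1-fold lower number from compound 2 to compound 3 (0.03 log units; within the scatter), which means that in this pair the presence of the methyl on the three-membered ring matters, while the way it points makes no visible difference. One feature makes this comparison a clean test of arrangement alone: the fact that compounds 2 and 3 differ only in the configuration as drawn.

The compounds shown leave open whether the loss is particular to methyl or would also follow from another group on the same saturated ring carbon, such as an ethyl chain or a hydroxymethyl group, and whether such a group would give a number close to those of compound 2 and compound 3 or a still higher one. From the compounds shown here alone, what lies behind the loss also stays open: these numbers record only how strongly each compound acts in the cells.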